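Pyrimidine benzyl ethers: cyano for fluoro on the phenyl

A few compounds are considered here, and "the series" means these few. Any claim that something is new, unique, unknown or untested is made for them only; others in the source may bear on it.

Measured compounds:
compound 1 `C[C@@H]1CN(C(=O)OC(C)(C)C)CCN1c1ncc(OCC2CCN(S(C)(=O)=O)CC2)cn1` — 78 nM
compound 2 `C[C@@H]1CN(C(=O)OC(C)(C)C)CCN1c1ncc(OCc2ccc(-n3cnnn3)cc2)cn1` — 33 nM
compound 3 `C[C@@H]1CN(C(=O)OC(C)(C)C)CCN1c1ncc(OCc2ccc(S(C)(=O)=O)cc2F)cn1` — 34 nM

In a functional assay for agonist activity at Glucose-dependent insulinotropic receptor (Mus musculus), read by HTRF and cAMP accumulation, with a stated time of 45 min (on this read-out lower numbers stand for an effect already at smaller amounts and higher numbers for an effect only at larger amounts of compound), compound 3 gives 34 nM. Compound 3 stands second highest of the three numbers; against compound 2 the gap is within the scatter (a 1.0-fold higher number from compound 2 to compound 3 (0.01 log units; within the scatter)), while against compound 1 the step is beyond it (a 2.3-fold lower number from compound 1 to compound 3 (0.36 log units; beyond the scatter)), much as a 2.4-fold lower number from compound 1 to compound 2 (0.37 log units; beyond the scatter) was. Compound 4 `C[C@@H]1CN(C(=O)OC(C)(C)C)CCN1c1ncc(OCc2ccc(S(C)(=O)=O)cc2C#N)cn1` differs from compound 3 in one place: cyano in place of fluoro on an aromatic carbon.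

Among the compounds with values here, no measured step alters a substituent on this phenyl ring; the recorded steps exchange the whole group on the chain carbon bound to the ring oxygen, and the two aryl groups of compound 2 and compound 3 gave numbers within the scatter of each other. The expected step in this assay is therefore small: a 1.0-fold higher number from compound 3 to compound 4 (0.01 log units; within the scatter) is estimated, none beyond the scatter. For compound 4 the expected value is 35 nM, with a range from 15 nM to 85 nM.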

Compound 4, half-maximal effective concentration: 131 nM
Estimate against measurement, compound 4: 3.7-fold (0.57 log units) below; the measured number lies above the stated range.
By their numbers in this assay, from the lowest: compounds 2 and 3 (each within the scatter of the next); then compounds 1 and 4 (each within the scatter of the next).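

In this assay, within the data shown here, cyano in place of fluoro gives a 3.9-fold higher number from compound 3 to compound 4 (0.59 log units; beyond the scatter), the first reading for a single substituent change on this phenyl ring. A small exchange on an aromatic carbon ortho to a large group thus moves the number beyond the scatter, whereas the whole aryl exchange between compound 2 and compound 3 did not. No measurement here accounts for this step.

From the compounds shown here alone, whether the rise is peculiar to cyano remains open, as chloro, methyl or methoxy on this carbon would show. Also open, going by these compounds, is whether the same exchange behaves alike with the 1H-tetrazol-1-yl group of compound 2.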